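The compounds below may be only part of what the source reports. "The series", "measured", "known", "first", "only" and "open" are said of these compounds alone.

Compound 1 `CCn1cc(C(=O)N2N=C(c3cc4ccccc4o3)CC2c2cccc([N+](=O)[O-])c2)c(=O)c2ccc(C)nc21` was tested in an ADME assay on Vero cells (Chlorocebus sabaeus) for cytotoxicity, read by MTT assay, with a stated time of 72 h (a lower number here means a stronger inhibitor, a higher number a weaker inhibitor), and gave > 164000 nM, which is a limit of the measurement rather than a number. Compound 2 `CCn1cc(C(=O)N2N=C(c3cc4ccccc4o3)CC2c2ccc(OC)cc2)c(=O)c2ccc(C)nc21` gave > 156000 nM in this assay, again only a limit. Both values are limits, so the step that the two limits leave unreadable from compound 1 to compound 2 cannot be sized, and compound 2 stands at a limit with no exact position. Compound 3 `CCn1cc(C(=O)N2N=C(c3cc4ccccc4o3)CC2c2ccccc2)c(=O)c2ccc(C)nc21` differs from compound 2 by hydrogen in place of methoxy on an aromatic carbon. No readable measured step bears on this change, so the step that the limit leaves unreadable from compound 2 to compound 3 is expected to be nothing beyond the scatter. Compound 3 is therefore estimated at 200000 nM, within 80000 nM to 500000 nM, most probably reported again as a limit.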

Compound 3, half-maximal inhibitory concentration: > 210000 nM
Compound 3: no number, only a limit; the forecaster's own chance of this, stated with the estimate: 80%; middle value at least 1.0-fold (0.02 log units) from the limit.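

Compound 3 gives only a limit, as do compound 1 and compound 2, and no step among these three compounds can be read in this assay. The compounds shown leave open what exact value any of them would have.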